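The compounds below may be only part of what the source reports. "The series", "measured", "known", "first", "only" and "open" are said of these compounds alone.

Working notes on the series.

Three compounds have been run in an ADME assay on MCF-10A cells (Homo sapiens) for cytotoxicity, read by sulforhodamine B assay, with a stated time of 48 h; on this read-out higher numbers stand for weaker inhibition of growth and lower numbers for stronger inhibition of growth. Compound 1, `O=C1C(=O)N(CN2CCN(c3ccnc4cc(C(F)(F)F)ccc34)CC2)c2cc(Cl)ccc21`, gives 32800 nM in this assay. Compound 2, `O=C1C(=O)N(CN2CCN(c3ccnc4cc(C(F)(F)F)ccc34)CC2)c2cc(Br)ccc21`, gives 24500 nM in this assay. The change from compound 1 to compound 2 is bromo in place of chloro on an aromatic carbon and the step it made was a 1.3-fold lower number from compound 1 to compound 2 (0.13 log units; within the scatter), so nothing is read into the direction.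

Compound 3, `NC(=S)N/N=C1\C(=O)Nc2cc(Cl)ccc21`, belongs to a different core; the difference between the two cores is not broken down here. In this assay compound 3 gives 48500 nM. Set against compound 1 and compound 2, the gaps are within the scatter, so no ordering of the two cores is claimed.

Compound 4, `NC(=S)N/N=C1\C(=O)Nc2cc(Br)ccc21`, has not yet been measured in this assay. Within the data shown here, it differs from compound 3 by bromo in place of chloro on an aromatic carbon, which is the same change as the one from compound 1 to compound 2, at a place described in identical words. The expectation for compound 4 therefore rests on compound 1 and compound 2, whose step was a 1.3-fold lower number from compound 1 to compound 2 (0.13 log units; within the scatter), and the step from compound 3 to compound 4 is expected to be a 1.3-fold lower number from compound 3 to compound 4 (0.12 log units; within the scatter), essentially flat. With one prior example only, the range is kept wide. The estimated value for compound 4 in this assay is 37000 nM, between 18000 nM and 80000 nM.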

Compound 4, concentration for 50% growth inhibition: 32000 nM
For compound 4 the middle estimate is 1.2-fold (0.06 log units) above the measured one; measured number inside the range.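

In this assay the new pair gives a 1.5-fold lower number from compound 3 to compound 4 (0.18 log units; within the scatter), so bromo in place of chloro on an aromatic carbon moves the number by no more than the scatter on the core of compound 3. Set beside the earlier pair, the two steps agree in size within the scatter of two such steps: the same change on two cores in this assay, a 1.3-fold lower number (0.13 log units; within the scatter) from compound 1 to compound 2 and a 1.5-fold lower number (0.18 log units; within the scatter) from compound 3 to compound 4, 1.1-fold (0.05 log units) apart, within the scatter of two such steps. This shows that, across these two cores, the change behaves alike in the sense that it stays small on both; it does not show that a real effect of the change carries from one core to the other, since each step alone lies within the scatter and even its direction cannot be relied on, and two cores are too few to speak for the series.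

The compounds shown hold only chloro or bromo at this aromatic carbon, so it remains open whether a fluoro, a methoxy, a nitrile or an amine there would give a step beyond the scatter on either core. Also open, from the compounds shown here alone, is whether such a larger step, if one exists, would keep its size when carried between the core of compound 1 and the core of compound 3.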